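The compounds below may be only part of what the source reports. "The series", "measured", "known", "first", "only" and "open" are said of these compounds alone.

Measured so far:
compound 1, `C#CCO[C@@H]1C=CC(=O)[C@@H](CO)O1`: in a functional assay on MCF7 cells (Homo sapiens) for inhibition, read by MTT assay, with a stated time of 72 h (on this read-out higher numbers stand for weaker inhibition and lower numbers for stronger inhibition), compound 1 gives 10400 nM.
compound 2, `C#CCCO[C@@H]1C=CC(=O)[C@@H](CO)O1`: in this assay compound 2 gives "not determined" (no result reported), so no result is on record for it.

Going by the values given here, compound 2 therefore stands nowhere on the numbers: it has no value of its own, and the only number belongs to compound 1. Compound 3, `C=CCO[C@@H]1C=CC(=O)[C@@H](CO)O1`, differs from compound 2 by vinyl in place of propargyl on a saturated chain carbon bound to an oxygen on a saturated carbon; cut one bond further out, the same change reads but-3-yn-1-yl to allyl. Among the compounds with values here, no measured pair shows what this change does, so the size and direction of the step from compound 2 to compound 3 in this assay cannot be drawn from the series, and nothing here argues for a step beyond the scatter in either direction. With compound 2 unmeasured, the expectation for compound 3 rests on compound 1, whose value 10400 nM is the sole anchor in this assay. Compound 3 is expected to give about 10000 nM in this assay, with a likely range from 3000 nM to 35000 nM.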

Compound 3, half-maximal inhibitory concentration: 16300 nM
For compound 3 the middle estimate is 1.6-fold (0.21 log units) below the measured one; the measured number falls inside the stated range.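

In this assay, going by these compounds alone, the first readable step at this position, vinyl in place of ethynyl on a saturated chain carbon bound to an oxygen on a saturated carbon, is a 1.6-fold higher number from compound 1 to compound 3 (0.20 log units; within the scatter), so this read-out does not separate compound 1 from compound 3. For these two compounds, the triple bond of the side chain can give way to a double bond without a step beyond the scatter. No measured data bear on why this exchange gives a step of this size.

With no result for compound 2, the steps involving it cannot be read, and the but-3-yn-1-yl chain stays without a value. Also open, from the compounds shown here alone, is whether a saturated propyl chain, a longer chain or a terminal amine at this position would give a step beyond the scatter.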